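Swapping a Methoxyphenyl for Furan on a Weak Cytotoxic Core

The compounds below may be only part of what the source reports. "The series", "measured", "known", "first", "only" and "open" are said of these compounds alone.

Compound 1 `COc1ccccc1-c1nnc(SCCn2c([N+](=O)[O-])cnc2C)o1`: 30500 nM
Compound 2 `COc1cc(-c2nnc(SCCn3c([N+](=O)[O-])cnc3C)o2)cc(OC)c1OC`: 34800 nM

In a functional assay on SGC-7901 cells (Homo sapiens) for cytotoxicity, read by MTT assay, with a stated time of 48 h (on this read-out lower numbers stand for stronger inhibition and higher numbers for weaker inhibition), compound 1 gives 30500 nM and compound 2 gives 34800 nM; the two numbers lie within the scatter of each other, so compound 1 does not stand apart. Compound 3 `Cc1ncc([N+](=O)[O-])n1CCSc1nnc(-c2ccco2)o1` is not yet measured. It differs from compound 1 by furan-2-yl in place of 2-methoxyphenyl on an aromatic carbon. Among the measured compounds shown here, no measured pair shows what such a change does, and both known values sit close together. The expected step is a 1.1-fold higher number from compound 1 to compound 3 (0.06 log units; within the scatter), that is, none beyond the scatter. For compound 3 the estimate is 35000 nM, with a range from 12000 nM to 100000 nM.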

Compound 3, half-maximal inhibitory concentration: 31700 nM
The estimate for compound 3 lay 1.1-fold (0.04 log units) above the measured number; the measured number falls inside the stated range.
By their numbers in this assay, from the lowest: compounds 1, 3 and 2 (each within the scatter of the next).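

In this assay, among the compounds shown here, furan-2-yl in place of 2-methoxyphenyl gives a 1.0-fold higher number from compound 1 to compound 3 (0.02 log units; within the scatter), the first measured step at this position. A five-membered aromatic ring with 1 hetero atom can therefore replace a six-membered aromatic ring of carbon only here with no shift beyond the scatter, though the activity remains weak. Nothing measured here accounts for this result. On these data alone, whether an amine or a carboxylic acid at this position would move the number beyond the scatter remains open. So does the effect of a longer chain elsewhere on the shared core.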